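The source may hold more compounds than are shown below. What is called first, only, known or untested is meant among the compounds shown, and "the series" means these compounds.

Measured so far in a functional assay on NSCLC cells (Homo sapiens) for cytotoxicity, with a stated time of 48 h; a higher number here means a weaker inhibitor of growth, a lower number a stronger inhibitor of growth:

compound 1, `COc1c(/C=C2/C(=O)Nc3ccc(Cl)cc32)c2ccccc2n1-c1ccccc1`, compound 1 gives 9550 nM
compound 2, `COc1cc2c(cc1C)NC(=O)/C2=C/c1c(Cl)n(Cc2cc(OC)c(OC)c(OC)c2)c2cc(C)c(OC)cc12`, compound 2 gives 11000 nM
compound 3, `O=C1/C(=C/c2c(Cl)[nH]c3ccccc23)c2ccccc2N1Cc1ccccc1`, compound 3 gives 6610 nM

Compound 2 carries the highest of the three numbers in this assay, but the spread across the set is small: its nearest neighbour is compound 1 and its furthest is compound 3, and both gaps sit within the usual scatter of repeated measurements. On these numbers the three compounds are therefore not separated from one another, and no ordering among them can be read off. For the measured compounds named here, no pair among the measured compounds differs in a single place, so no measured step is available to calibrate the change under consideration.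

The next compound is compound 4, `COc1ccc2c(c1)/C(=C\c1c(Cl)n(Cc3cc(OC)c(OC)c(OC)c3)c3cc(C)c(OC)cc13)C(=O)N2`, which is to be measured in this assay. Relative to compound 2 it differs in one place: hydrogen in place of methyl on an aromatic carbon. Going by the values given here, the loss of a single carbon with no change to ring count, hydrogen-bond donors or acceptors, or charge is a small edit, and nothing among the measured compounds speaks to its effect.

Among the compounds with values here, with no measured step to lean on, the expected step from compound 2 to compound 4 is a 1.1-fold lower number from compound 2 to compound 4 (0.04 log units; within the scatter), that is, none beyond the scatter in either direction. Compound 4 is accordingly estimated at 10000 nM, with a range from 4000 nM to 25000 nM.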

Compound 4, concentration for 50% growth inhibition: 20400 nM
Estimate against measurement, compound 4: 2.0-fold (0.31 log units) below; measured number inside the range.
By their numbers in this assay, from the lowest: compounds 3, 1, 2 and 4 (each within the scatter of the next, the first and the last beyond it).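

Hydrogen in place of methyl on this aromatic carbon, ortho to a methoxy group, provides the first single-place step in the series: in this assay the change reads a 1.9-fold higher number from compound 2 to compound 4 (0.27 log units; within the scatter) and so does not separate the two compounds. The methyl at this place is therefore not shown to be required for the growth inhibition read here, and the step sets no direction for this edit, although it rests on a single pair on a single core. No available measurement bears on what lies behind this result.

Only hydrogen and methyl are shown at this carbon, so it remains open whether a fluorine, an amine, a carboxylic acid or a longer chain such as ethyl or propyl would give a step beyond the scatter. As far as these compounds go, it is also open whether the same exchange of methyl for hydrogen would read the same way on the cores of compound 1 or compound 3, or at the other carbons of this six-membered aromatic ring.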